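The source may report more compounds than this note shows. Statements on the series, on what has been measured and on what is new or still open speak of the compounds shown alone.

Measured compounds:
compound 1, `Cn1c(=O)[nH]c2nc(SCC(=O)c3ccc(Cl)cc3)[nH]c2c1=O`: 6100 nM
compound 2, `Cn1c(=O)[nH]c2nc(SCC(=O)c3ccc(Br)cc3)[nH]c2c1=O`: 9700 nM
compound 3, `Cn1c(=O)c2[nH]c(SC/C(=N/O)c3ccc(Cl)cc3)nc2n(C)c1=O`: 1300 nM

In a functional assay on PANC-1 cells (Homo sapiens) for inhibition, read by MTT assay, with a stated time of 48 h (on this read-out lower numbers stand for stronger inhibition and higher numbers for weaker inhibition), compound 1 gives 6100 nM and compound 2 gives 9700 nM. The two differ in one place, (bromo in place of chloro on an aromatic carbon), and the step is a 1.6-fold higher number from compound 1 to compound 2 (0.20 log units; within the scatter); the two values are therefore read as equal within the scatter of this assay, and no order between them is claimed.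

Compound 3 carries a different core, and the difference between the core of compound 1 and that of compound 3 is not broken down here. In this assay compound 3 gives 1300 nM, the lowest number of the three; its gaps to compound 1 and to compound 2 both lie beyond the scatter, so compound 3 is the strongest inhibitor among the measured compounds.

Compound 4, `Cn1c(=O)c2[nH]c(SC/C(=N/O)c3ccc(Br)cc3)nc2n(C)c1=O`, is not yet measured. It differs from compound 3 by bromo in place of chloro on an aromatic carbon, and the place where the change occurs is described in the same words as for the change from compound 1 to compound 2, so the two are taken as the same change on two cores. For the measured compounds named here, only one earlier instance of this change exists, and it lies within the scatter. The expected step in this assay is a 1.5-fold higher number from compound 3 to compound 4 (0.19 log units; within the scatter), resting on compound 1 and compound 2 with their step of a 1.6-fold higher number from compound 1 to compound 2 (0.20 log units; within the scatter). Compound 4 is thus estimated at 2000 nM, with a range from 1000 nM to 4500 nM.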

Compound 4, half-maximal inhibitory concentration: 1700 nM
Estimate against measurement, compound 4: 1.2-fold (0.07 log units) above; low and high end bracket the measured number.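

Carried to a second core, bromo in place of chloro on an aromatic carbon gives a 1.3-fold higher number from compound 3 to compound 4 (0.12 log units; within the scatter) in this assay, so no order is claimed between the two compounds. Set beside the earlier instance, the change reads the same on both cores: the same change on two cores in this assay, a 1.6-fold higher number (0.20 log units; within the scatter) from compound 1 to compound 2 and a 1.3-fold higher number (0.12 log units; within the scatter) from compound 3 to compound 4, 1.2-fold (0.08 log units) apart, within the scatter of two such steps

This shows that, in this one assay, exchanging 4-chlorophenyl for 4-bromophenyl leaves the number within the scatter on each of these two cores, and that the step on one core would have served as a fair guide to the step on the other. It does not show that the exchange is without any effect, since steps this small cannot separate a slight real shift from repeat noise, and two pairs with a single halogen exchange do not establish transfer to any further core or to any other substituent.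

Open, on these data alone, is whether a fluoro, a methoxy, an amine or a carboxylic acid on the same aromatic carbon, para to a large group, would give a step beyond the scatter, and whether such a step would hold across both cores. For the compounds shown here, also open is which part of the difference between the two cores goes with the lower numbers on the second one, as no pair here isolates a single change in the core.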